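A few compounds are considered here, and "the series" means these few. Any claim that something is new, unique, unknown or untested is made for them only; others in the source may bear on it.

Values in a functional assay on PC-3 cells (Homo sapiens) for antiproliferative activity, read by MTT assay, with a stated time of 24 h; a lower number here means a stronger inhibitor, a higher number a weaker inhibitor:
compound 1 `CCn1c(C(=O)N[C@@H](CC(=O)OC)C(=O)OC)ccc1C(CC)(CC)c1ccc(OCS(=O)(=O)c2ccccc2)c(C)c1`: 6490 nM
compound 2 `CCn1c(C(=O)NCCNC(=O)OC(C)(C)C)ccc1C(CC)(CC)c1ccc(OCS(=O)(=O)c2ccccc2)c(C)c1`: > 50000 nM
compound 3 `CCn1c(C(=O)N[C@H](C)CO)ccc1C(CC)(CC)c1ccc(OCS(=O)(=O)c2ccccc2)c(C)c1`: 7790 nM

The value for compound 2 is a limit of the assay, not a number. Compound 3 stands level with compound 1, as the data show a 1.2-fold higher number from compound 1 to compound 3 (0.08 log units; within the scatter). Compound 4 `CCn1c(C(=O)N[C@H](CO)CCCO)ccc1C(CC)(CC)c1ccc(OCS(=O)(=O)c2ccccc2)c(C)c1` is compound 3 with one change on the amide-type nitrogen: a group of 7 heavy atoms (5 carbon, 2 oxygen; no ring) in place of a group of 4 heavy atoms (3 carbon, 1 oxygen; no ring), on an amide-type nitrogen.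

Three measured steps involve this same nitrogen. The one between the two numbered values is a 1.2-fold higher number from compound 1 to compound 3 (0.08 log units; within the scatter), even though the groups exchanged there differ considerably. The two steps involving the 2-((tert-butoxycarbonyl)amino)ethyl group are larger: an at least 7.7-fold higher number from compound 1 to compound 2 (0.88 log units; beyond the scatter) and an at least 6.4-fold lower number from compound 2 to compound 3 (0.80 log units; beyond the scatter). Compound 4 carries no such group, so its closest guide is the step to compound 3, and no step beyond the scatter is expected in this assay, in either direction. The estimate means an expected 1.2-fold higher number from compound 3 to compound 4 (0.06 log units; within the scatter). The expected value for compound 4 is 9000 nM, with an estimated range from 3500 nM to 25000 nM.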

Compound 4, half-maximal inhibitory concentration: 6810 nM
The estimate for compound 4 lay 1.3-fold (0.12 log units) above the measured number; the range from low to high includes it.
By their numbers in this assay, from the lowest: compounds 1, 4 and 3 (each within the scatter of the next). At a limit, above all of these: compound 2.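

In this assay, the group of 7 heavy atoms, with 2 hydrogen-bond donors, can stand in place of 1-(hydroxymethyl)ethyl on the amide-type nitrogen with a 1.1-fold lower number from compound 3 to compound 4 (0.06 log units; within the scatter), and in place of 1,2-bis(methoxycarbonyl)ethyl with a 1.0-fold higher number from compound 1 to compound 4 (0.02 log units; within the scatter), so a third, differently built group joins the two already level. The 2-((tert-butoxycarbonyl)amino)ethyl group alone stands apart, with an at least 7.3-fold lower number from compound 2 to compound 4 (0.86 log units; beyond the scatter). The value of compound 2 is a limit of the assay, not a number: the limit of > 50000 nM in this assay, at which 1 of the 4 values shown sits.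

The compounds shown leave open how a free amine at the end of the ethyl chain, or a carboxylic acid in place of the methyl esters, would read in this assay. They also leave open whether a longer chain on this nitrogen would stay level with compound 4.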